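Changing the phenyl group: what permeability to expect

This account rests on a few compounds, and the source may have more. Where it says the series, first, only, none or still open, it means among the compounds named here.

Compound 1 `Cc1oc(-c2c(Br)cccc2Br)nc1CN1CCC(C(=O)NCCCN2C[C@H](C)C[C@H](C)C2)CC1`: in a physicochemical assay for permeability, using PAMPA (a lower number here means that the compound crosses the layer more slowly, a higher number that the compound crosses the layer faster), compound 1 gives < 1 10^-6 cm/s, a limit of the assay rather than a number.
Compound 2 `Cc1cccc(-c2nc(CN3CCC(C(=O)NCCCN4C[C@H](C)C[C@H](C)C4)CC3)c(C)o2)c1`: in this assay compound 2 gives 279 10^-6 cm/s.

Compound 2 stands with the only number shown. The value of compound 1 is a limit, (the limit of < 1 10^-6 cm/s in this assay, at which 1 of the 2 values shown sits).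

Compound 3 `COc1cccc(Cl)c1-c1nc(CN2CCC(C(=O)NCCCN3C[C@H](C)C[C@H](C)C3)CC2)c(C)o1` differs from compound 2 by 2-chloro-6-methoxyphenyl in place of 3-methylphenyl on an aromatic carbon. Among the measured compounds shown here, the only measured step at this place is an at least 270-fold higher number from compound 1 to compound 2 (2.44 log units; beyond the scatter), which shows that the group here can shift the number greatly. No measurement covers 2-chloro-6-methoxyphenyl itself, so the guess is uncertain. For compound 3 the expected step is a 4.7-fold lower number from compound 2 to compound 3 (0.67 log units; beyond the scatter). Compound 3 is expected to give about 60 10^-6 cm/s in this assay, within 8 10^-6 cm/s to 250 10^-6 cm/s.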

Compound 3, apparent permeability: 51 10^-6 cm/s
Compound 3: middle estimate off by 1.2-fold (0.07 log units), on the high side; low and high end bracket the measured number.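

Swapping 2,6-dibromophenyl for 2-chloro-6-methoxyphenyl gives an at least 51-fold higher number from compound 1 to compound 3 (1.70 log units; beyond the scatter), so a phenyl group with two substituents at this place need not leave the number at the floor of the assay. Yet 2-chloro-6-methoxyphenyl does not match 3-methylphenyl, with a 5.5-fold lower number from compound 2 to compound 3 (0.74 log units; beyond the scatter). The value of compound 1 is still a limit, so the first step has no exact size: the limit of < 1 10^-6 cm/s in this assay, at which 1 of the 3 values shown sits.

The compounds shown leave open whether the chlorine or the methoxy goes with the lower number. A 2-chlorophenyl or a 2-methoxyphenyl group alone would separate the two.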